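This account rests on a few compounds, and the source may have more. Where it says the series, first, only, none or still open, it means among the compounds named here.

Measured so far:
- compound 1, `Cc1nn(C)c(Oc2ccc(I)cc2)c1/C=N\CCCCCOc1cc2oc(=O)cc(C)c2cc1Cl`: > 25000 nM
- compound 2, `Cc1nn(C)c(Oc2ccccc2F)c1/C=N\CCCCCCOc1cc2oc(=O)cc(C)c2cc1Cl`: > 25000 nM

Both values come from a functional assay on HepG2 cells (Homo sapiens) for antiproliferative activity, read by MTT assay, with a stated time of 72 h (on this read-out lower numbers stand for stronger inhibition and higher numbers for weaker inhibition), and both are limits of the assay rather than numbers. For compound 2 the value is > 25000 nM, a limit. For compound 1 the value is > 25000 nM, also a limit. Going by the values given here, compound 2 thus stands at the limit, level with the only other value shown: the limit of > 25000 nM in this assay, at which 2 of the 2 values shown sit. Among the compounds with values here, no step between two measured compounds is available, so nothing yet tells how any structural change moves this assay.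

Compound 3, `Cc1nn(C)c(Oc2ccc(F)cc2)c1/C=N\CCCCCCOc1cc2oc(=O)cc(C)c2cc1Cl`, has not yet been measured in this assay. It differs from compound 2 in one place: 4-fluorophenyl in place of 2-fluorophenyl on an oxygen on an aromatic ring. Neither the value of compound 2 nor that of compound 1 gives a number from which this change could be sized. With compound 2 at the limit, the expected step from compound 2 to compound 3 is a step that the limit leaves unreadable from compound 2 to compound 3, meaning nothing beyond the scatter, and the result is expected most likely to come back as a limit again. The estimate for compound 3 in this assay is 30000 nM, with a range from 8000 nM to 120000 nM.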

Compound 3, half-maximal inhibitory concentration: 12500 nM
Estimate against measurement, compound 3: 2.4-fold (0.38 log units) above; the range from low to high includes it.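

In this assay, going by these compounds alone, compound 3 gives 12500 nM, the only value shown that is a number and not a limit, so this position now has its first readable result. The two groups hold the same atoms, and 4-fluorophenyl in place of 2-fluorophenyl on an oxygen on an aromatic ring gives an at least 2.0-fold lower number from compound 2 to compound 3 (0.30 log units; that floor lies within the scatter), so the change can be stated only as a floor and not as a size, and that floor alone does not separate the two compounds. The true size of the step stays unread because compound 2 sits at a limit of the assay: the limit of > 25000 nM in this assay, at which 2 of the 3 values shown sit.

Compound 1 differs from compound 2 and from compound 3 in more than one place, so it gives no separate reading on the halogen or on the chain. Also open, as far as these compounds go, is how an unsubstituted phenyl, a methoxy group or an amine in place of the fluorine, or a longer chain on the shared core, would read in this assay.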